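The source may hold more compounds than are shown below. What is called first, only, known or untested is meant among the compounds shown, and "the series" means these compounds.

Measured compounds:
Compound 1 `CC(C)n1ncc2c(C(=O)Nc3c(F)cc(F)cc3F)cc(-c3cccs3)nc21`: in an ADME assay on LLC-MK2 cells (Macaca mulatta) for cytotoxicity, read by spectrophotometry and crystal violet staining, with a stated time of 4 days (on this read-out lower numbers stand for higher toxicity in this test and higher numbers for lower toxicity in this test), compound 1 gives > 200000 nM, a limit of the assay.
Compound 2 `CC(C)n1ncc2c(C(=O)Nc3cccc(F)c3F)cc(-c3cccs3)nc21`: in this assay compound 2 gives 75000 nM.
Compound 3 `CC(C)n1ncc2c(C(=O)Nc3c(F)cccc3F)cc(-c3cccs3)nc21`: in this assay compound 3 gives > 200000 nM, again a limit.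

Compound 1 stands at the limit (the limit of > 200000 nM in this assay, at which 2 of the 3 values shown sit), so only a bound is known for it, not a number. Going by the values given here, compound 2 is the only compound with a numerical value; the step of an at least 2.6-fold lower number from compound 1 to compound 2 (0.42 log units; beyond the scatter) reads as a move toward higher toxicity, the step of an at least 2.6-fold higher number from compound 2 to compound 3 (0.42 log units; beyond the scatter) as a move back to the limit, and the step that the two limits leave unreadable from compound 1 to compound 3 cannot be sized at all.

Compound 4 `CC(C)n1ncc2c(C(=O)Nc3cccc(C(N)=O)c3)cc(-c3cccs3)nc21` differs from compound 1 by 3-carbamoylphenyl in place of 2,4,6-trifluorophenyl on an amide-type nitrogen. Among the compounds with values here, none of the measured steps bears on this kind of change: each of them trades one fluoro pattern on the aryl amide for another, whereas here the fluorines leave altogether and a carbamoyl group enters. The measured steps give no direction for such a change, and two of the three compounds sit at the limit. Compound 4 is therefore expected to stay near the limit, with the step of a number no higher from compound 1 to compound 4 (the limit leaves the size open) expected to be small or unreadable. The estimate for compound 4 in this assay is 200000 nM, within the range 60000 nM to 400000 nM.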

Compound 4, half-maximal cytotoxic concentration: 25000 nM
The estimate for compound 4 lay 8.0-fold (0.90 log units) above the measured number; measured number below the stated range.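

The position on the amide-type nitrogen is not confined to the limit in this assay: a non-fluorinated aryl group with a carbamoyl substituent gives the lowest number of the four compounds, with every step to it beyond the scatter. Against the one compound with a numerical partner value, 3-carbamoylphenyl gives a real shift toward higher toxicity (a 3.0-fold lower number from compound 2 to compound 4 (0.48 log units; beyond the scatter)). The steps from the two fluorinated compounds held at the limit are open-ended (an at least 8.0-fold lower number from compound 1 to compound 4 (0.90 log units; beyond the scatter); an at least 8.0-fold lower number from compound 3 to compound 4 (0.90 log units; beyond the scatter)), and their full size stays unknown: the limit of > 200000 nM in this assay, at which 2 of the 4 values shown sit.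

Going by these compounds, whether the step follows the carbamoyl group itself or the loss of the fluoro substituents remains open. An unsubstituted phenyl would separate these two readings, and a carboxylic acid or an amine in place of the carbamoyl group would test how specific the shift is.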